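The source may hold more compounds than are shown below. What is called first, only, known or untested is meant among the compounds shown, and "the series" means these compounds.

Working notes, quinazoline sulfonamide pair and one new analogue. Compound 1 `COc1cc2nc(N3CCN(S(=O)(=O)c4ccc(S(C)(=O)=O)cc4)CC3)nc(N)c2cc1OC` and compound 2 `COc1cc2nc(N3CCN(S(=O)(=O)c4cccc5ccccc45)CC3)nc(N)c2cc1OC` are measured; compound 3 `COc1cc2nc(N3CCN(S(=O)(=O)c4ccc(-c5ccccc5)cc4)CC3)nc(N)c2cc1OC` is not. Among the compounds with values here, in a functional assay on PC-3 cells (Homo sapiens) for inhibition (on this read-out lower numbers stand for stronger inhibition and higher numbers for weaker inhibition), compound 1 gives 17000 nM and compound 2 gives 14000 nM; compound 2 stands level with compound 1, the only step being a 1.2-fold lower number from compound 1 to compound 2 (0.08 log units; within the scatter). Compound 3 differs from compound 2 by 4-phenylphenyl in place of naphthalen-1-yl on a sulfonyl sulfur. Within the data shown here, only that one step, a change of the group on the same sulfonyl sulfur, bears on it, and it stayed within the scatter, so for the new change no step beyond the scatter is expected either, a 1.1-fold lower number from compound 2 to compound 3 (0.03 log units; within the scatter). Compound 3 is therefore expected at 13000 nM, with a range of 4000 nM to 40000 nM.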

Compound 3, half-maximal inhibitory concentration: 4200 nM
Estimate against measurement, compound 3: 3.1-fold (0.49 log units) above; low and high end bracket the measured number.
By their numbers in this assay, from the lowest: compound 3; then compounds 2 and 1 (each within the scatter of the next).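

In this assay, the group on the sulfonyl sulfur now shows a step beyond the scatter: 4-phenylphenyl in place of naphthalen-1-yl gives a 3.3-fold lower number from compound 2 to compound 3 (0.52 log units; beyond the scatter), although both groups hold two six-membered aromatic rings of carbon only, so that ring count alone does not set the number. Phenyl in place of methylsulfonyl on an aromatic carbon gives a 4.0-fold lower number from compound 1 to compound 3 (0.61 log units; beyond the scatter). Nothing available explains either step.

Still open, from the compounds shown here alone, is whether an amine or a carboxylic acid on the added phenyl would keep the lower number. A longer carbon chain in place of that phenyl is equally unresolved.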